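Trifluoromethyl for methyl on the anilide of compound 2

A few compounds are considered here, and "the series" means these few. Any claim that something is new, unique, unknown or untested is made for them only; others in the source may bear on it.

Three anilides built on one core have been measured. In a functional assay on HEK293 cells for agonist activity at D(4) dopamine receptor (Homo sapiens), read by FLIPR (on this read-out higher numbers stand for larger maximal responses and lower numbers for smaller maximal responses), compound 1 `Cc1cc(C)cc(NC(=O)CN2CCC(c3cccc[n+]3[O-])CC2)c1` gives 76%, compound 2 `Cc1cc(F)ccc1NC(=O)CN1CCC(c2cccc[n+]2[O-])CC1` gives 84%, and compound 3 `O=C(CN1CCC(c2cccc[n+]2[O-])CC1)Nc1cccc(F)c1` gives 70%. Compound 2 holds the highest of the three numbers. Among the compounds with values here, the step of a number 8 percentage points higher from compound 1 to compound 2 (within the scatter) stays within the scatter, and a number 14 percentage points lower from compound 2 to compound 3 (beyond the scatter) is the only step that goes beyond the scatter. Compound 4 `O=C(CN1CCC(c2cccc[n+]2[O-])CC1)Nc1ccc(F)cc1C(F)(F)F` differs from compound 2 by trifluoromethyl in place of methyl on an aromatic carbon. Within the data shown here, none of the measured steps exchanges a methyl for a trifluoromethyl; all three swap one anilide for another, and two of them, a number 8 percentage points higher from compound 1 to compound 2 (within the scatter) and a number 6 percentage points lower from compound 1 to compound 3 (within the scatter), stay within the scatter, while the third is modest. Changes to this part of the molecule have therefore moved this assay little, and the account expects that compound 4 will behave likewise, with a step of a number 6 percentage points lower from compound 2 to compound 4 (within the scatter) that is expected to remain within the scatter. The efficacy of compound 4 in this assay is estimated at 78%, with a range from 62% to 92%.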

Compound 4, largest response reached (reported as efficacy), in percent of the reference or control that the assay uses: 65%
Compound 4: middle estimate off by 13 percentage points, on the high side, and the stated range covers the measured number.
By their numbers in this assay, from the lowest: compounds 4, 3, 1 and 2 (each within the scatter of the next, the first and the last beyond it).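

The exchange of methyl for trifluoromethyl on an aromatic carbon, ortho to a large group and meta to a fluoro group, shows that this position of the anilide is not indifferent in this assay. Within the data shown here, the step of a number 19 percentage points lower from compound 2 to compound 4 (beyond the scatter) goes beyond the scatter with the fluoro group left in place, whereas the only earlier step to do so, a number 14 percentage points lower from compound 2 to compound 3 (beyond the scatter), changed the anilide in more than one place, so a change at this single aromatic carbon is enough to take the response away from the number of compound 2, although compound 4 still gives 65% as a clear response. Nothing available here bears on why the number falls with this exchange.

The compounds shown leave open how the response would read with a chloro, an ethyl or a methoxy group on this aromatic carbon, and so whether the methyl of compound 2 is particular or one of several groups that would serve there. They also leave open whether a nitrile at this carbon would read nearer to compound 2 or nearer to compound 4.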